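The compounds below may be only part of what the source reports. "The series", "measured", "known", "first", "only" and "open" are said of these compounds alone.

Working notes on the series. Two compounds have numbers in an assay on isolated protein for inhibition of Discoidin domain-containing receptor 2 (Homo sapiens), read by ELISA, with a stated time of 60 min; a higher number here means a weaker inhibitor, a lower number a stronger inhibitor. Compound 1 `Cc1ccc(C(=O)Nc2cccc(C(F)(F)F)c2)cc1-c1ccc2c(-c3ccc(C(=O)N4CCN(C)CC4)cc3)n[nH]c2c1` gives 6.5 nM in this assay. Compound 2 `Cc1ccc(C(=O)Nc2cccc(C(F)(F)F)c2)cc1-c1ccc2c(-c3cn[nH]c3)n[nH]c2c1` gives 55.6 nM in this assay, the higher of the two numbers, and the gap between compound 2 and compound 1 lies beyond the scatter. Compound 3 `Cc1ccc(C(=O)Nc2cccc(C(F)(F)F)c2)cc1-c1ccc2c(-c3cnn(C4CCOC4)c3)n[nH]c2c1` has not yet been measured in this assay. Compound 3 differs from compound 2 in one place: oxolan-3-yl in place of hydrogen on an aromatic nitrogen. For the measured compounds named here, no step between two measured compounds covers this change, so the expectation for compound 3 rests on the two numbers alone. Compound 1, carrying a larger group in the same region of the core, gives 6.5 nM, which points towards a modest gain rather than a loss. Compound 3 is therefore expected to come in at 25 nM in this assay, with a range of 8 nM to 80 nM, an expected step of a 2.2-fold lower number from compound 2 to compound 3 (0.35 log units; beyond the scatter).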

Compound 3, half-maximal inhibitory concentration: 6.2 nM
For compound 3 the middle estimate is 4.0-fold (0.61 log units) above the measured one, outside the stated range (below it).
By their numbers in this assay, from the lowest: compounds 3 and 1 (each within the scatter of the next); then compound 2.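

In this assay, this aromatic nitrogen takes a substituent: oxolan-3-yl in place of hydrogen gives a 9.0-fold lower number from compound 2 to compound 3 (0.95 log units; beyond the scatter), so the hydrogen on that nitrogen is not needed for a low number, at least with this one group. Compound 3 at 6.2 nM and compound 1 at 6.5 nM lie within the scatter of each other, which shows that the 1-(oxolan-3-yl)-1H-pyrazol-4-yl group and the much larger substituent of compound 1 reach the same range from the same core. Nothing at hand accounts for the size of this step.

Still open, on these data alone, is whether the step depends on the oxolane ring or would follow from any group on that nitrogen. A methyl group, a cyclopentyl ring without the ring oxygen, or a piperidin-4-yl ring carrying an amine would help separate these cases.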